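A few compounds are considered here, and "the series" means these few. Any claim that something is new, unique, unknown or untested is made for them only; others in the source may bear on it.

Measured so far in a functional assay on the whole organism with Mus musculus as the target; on this read-out higher numbers stand for an effect only at larger amounts of compound and lower numbers for an effect already at smaller amounts:
compound 1 `CCCNC(=O)Cn1c(-c2ccc(Cl)cc2)nc2cccnc21`: 37.5 mg/kg
compound 2 `O=C(Cn1c(-c2ccc(Cl)cc2)nc2cccnc21)N1CCCCC1`: 56.2 mg/kg
compound 3 `CN(C)CCN(C)C(=O)Cn1c(-c2ccc(Cl)cc2)nc2cccnc21`: 100 mg/kg

Compound 3 sits at the high end of these numbers: a 2.7-fold higher number from compound 1 to compound 3 (0.43 log units; beyond the scatter), while a 1.8-fold higher number from compound 2 to compound 3 (0.25 log units; within the scatter). The next compound, compound 4 `CN(C)CCCNC(=O)Cn1c(-c2ccc(Cl)cc2)nc2cccnc21`, is built from the same atoms joined differently: (3-(dimethylamino)propyl)amino in place of (2-(dimethylamino)ethyl)(methyl)amino on a carbonyl carbon. It carries the amide hydrogen found in compound 1 and the dimethylamino end found in compound 3.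

Going by the values given here, no measured step makes this exact swap, and no measured compound combines those two features. Among the compounds with values here, the closest evidence is a 2.7-fold higher number from compound 1 to compound 3 (0.43 log units; beyond the scatter), the only step beyond the scatter. Against it stands a 1.5-fold higher number from compound 1 to compound 2 (0.18 log units; within the scatter), a change on the same carbonyl carbon that stays within the scatter. A small shift towards a lower number is therefore expected, recovering only part of the first of these steps. The estimated change is a 1.7-fold lower number from compound 3 to compound 4 (0.22 log units; within the scatter). Compound 4 is expected at 60 mg/kg, with an estimated range from 30 mg/kg to 120 mg/kg.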

Compound 4, dose for half-maximal effect: 64 mg/kg
For compound 4 the middle estimate is 1.1-fold (0.03 log units) below the measured one; measured number inside the range.
By their numbers in this assay, from the lowest: compounds 1, 2, 4 and 3 (each within the scatter of the next, the first and the last beyond it).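

In this assay, (3-(dimethylamino)propyl)amino in place of (2-(dimethylamino)ethyl)(methyl)amino on a carbonyl carbon adds a hydrogen-bond donor with no change in heavy atoms and gives a step within the scatter (a 1.6-fold lower number from compound 3 to compound 4 (0.19 log units; within the scatter)). The two other new comparisons also stay within the scatter: dimethylamino in place of hydrogen on the chain (a 1.7-fold higher number from compound 1 to compound 4 (0.23 log units; within the scatter)) and (3-(dimethylamino)propyl)amino in place of piperidin-1-yl (a 1.1-fold higher number from compound 2 to compound 4 (0.06 log units; within the scatter)), so compound 4 separates from none of the other three compounds. Nothing measured here accounts for these numbers.

On these data alone, it remains open whether the gap between compound 1 and compound 3 (a 2.7-fold higher number from compound 1 to compound 3 (0.43 log units; beyond the scatter)) goes with the amide hydrogen or with the dimethylamino end. Also open, as far as these compounds go, is whether morpholin-4-yl or a longer chain on the carbonyl carbon would give a step beyond the scatter.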